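The compounds below may be only part of what the source reports. "The series", "measured", "known", "first", "only" and "open" are said of these compounds alone.

Measured compounds:
compound 1, `CCCCOC(=O)CC1c2cccc(C)c2S(=O)(=O)N1C(=O)c1ccc(C(F)(F)F)cc1`: 1310 nM
compound 2, `CCCCOC(=O)CC1c2cccc(C)c2S(=O)(=O)N1C(=O)c1cccc(C(F)(F)F)c1`: 1050 nM
compound 3, `CCCCOC(=O)CC1c2cc(F)cc(C)c2S(=O)(=O)N1C(=O)c1ccc(C(F)(F)F)cc1`: 9030 nM

In an assay on HEK-Blue hNOD1 cells for antagonist activity at Nucleotide-binding oligomerization domain-containing protein 1 (Homo sapiens), read by reporter gene assay, with stated times of 3 h and 20 h (a higher number here means a weaker inhibitor, a lower number a stronger inhibitor), compound 1 sits second highest of the three numbers. Its nearest neighbour is compound 2, where the step of a 1.2-fold lower number from compound 1 to compound 2 (0.10 log units; within the scatter) stays within the scatter, so the two are not told apart by this assay. Its furthest neighbour is compound 3, where the step of a 6.9-fold higher number from compound 1 to compound 3 (0.84 log units; beyond the scatter) is a modest loss.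

Compound 4, `Cc1cccc2c1S(=O)(=O)N(C(=O)c1ccc(C(F)(F)F)cc1)C2CC(=O)OC(C)(C)C`, has not yet been measured in this assay. It differs from compound 1 by tert-butyl in place of butyl on an oxygen next to a carbonyl group. Neither measured step bears on this change: the step from compound 1 to compound 2 moves the trifluoromethyl around the aromatic ring on the carbonyl carbon, and the step from compound 1 to compound 3 adds a fluoro to an aromatic carbon of the core; neither touches the ester. The data therefore give no direct guide to the effect of tert-butyl in place of butyl. Among the compounds with values here, with no bearing step, the expectation for compound 4 is a step of a 1.1-fold higher number from compound 1 to compound 4 (0.06 log units; within the scatter) from compound 1, that is, none beyond the scatter, while allowing a wide range. Compound 4 is thus estimated at 1500 nM, with a range from 500 nM to 4500 nM.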

Compound 4, half-maximal inhibitory concentration: 8120 nM
The estimate for compound 4 lay 5.4-fold (0.73 log units) below the measured number; the whole stated range lies below it.
By their numbers in this assay, from the lowest: compounds 2 and 1 (each within the scatter of the next); then compounds 4 and 3 (each within the scatter of the next).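

In this assay, the group on an oxygen next to a carbonyl group proves sensitive to change: tert-butyl in place of butyl gives a 6.2-fold higher number from compound 1 to compound 4 (0.79 log units; beyond the scatter). Butyl and tert-butyl hold the same atoms joined differently, so the way this chain is joined, with no change in its atoms, is enough to move the number beyond the scatter, something the earlier compounds could not show, as neither of their steps touched the ester. Nothing available here accounts for this loss.

The compounds shown leave open how other groups would behave at this place, such as a methyl or ethyl chain, a longer chain, or a free carboxylic acid in place of the ester, so the two chains present give no trend. They also leave open whether the change from butyl to tert-butyl would have a similar size with the 3-(trifluoromethyl)phenyl group of compound 2 or the fluoro-bearing core of compound 3.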